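A few compounds are considered here, and "the series" means these few. Any claim that something is new, unique, unknown or untested is made for them only; others in the source may bear on it.

Measured so far
compound 1 `COc1ccccc1-c1nnc(-c2cc3cc(Cl)ccc3o2)o1`: > 100000 nM
compound 2 `Cc1cc(Cl)ccc1OCc1nnc(-c2ccccc2OC(F)(F)F)o1`: "not active" (no number reported)

Both measured compounds were tested in an ADME assay on cells for inhibition of anoctamin-2 (Homo sapiens), read by fluorescence, with a stated time of 20 min; a lower number here means a stronger inhibitor, a higher number a weaker inhibitor. For compound 1 the reported value > 100000 nM is a limit of the assay and not a number, which is where the limit of > 100000 nM in this assay, at which 1 of the 2 values shown sits, sits. For compound 2 no number is reported at all in this assay; it is recorded only as "not active" (no number reported). For the measured compounds named here, compound 2 therefore stands nowhere on a numerical scale: the only other value shown beside it is the limit for compound 1, so the whole series so far lies at or beyond the reach of this assay.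

The next compound, compound 3 `COc1ccccc1-c1nnc(COc2ccc(Cl)cc2C)o1`, differs from compound 2 by methyl in place of trifluoromethyl on an oxygen on an aromatic ring; cut one bond further out, the change reads trifluoromethoxy to methoxy. Going by the values given here, no measured pair shows this change, so no size can be read off for it. Compound 2 being recorded as "not active" (no number reported), the step to compound 3 is expected to be none beyond the scatter in this assay, in no particular direction. Compound 3 is accordingly expected near 100000 nM, within 30000 nM to 300000 nM, most likely again as a limit.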

Compound 3, half-maximal inhibitory concentration: 12400 nM
Estimate against measurement, compound 3: 8.1-fold (0.91 log units) above; measured number below the stated range.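

No step can be read from compound 2 to compound 3: compound 2 has no number in this assay to set against compound 3 at 12400 nM. The compounds shown leave open what size the change from trifluoromethoxy to methoxy has between two numbers, and in which direction it runs.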